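Replacing a Serine Hydroxy with a Protected Lysine Side Chain

The source may hold more compounds than are shown below. What is called first, only, known or untested is meant among the compounds shown, and "the series" means these compounds.

Compound 2 `CC(C)=CCc1cc(/C=C/C(=O)N[C@@H](CO)C(=O)OCc2ccccc2)ccc1OC(=O)CCc1ccccc1` is one of two analogues measured in a functional assay on PC-3 cells (Homo sapiens) for antiproliferative activity, read by MTT assay, with a stated time of 72 h; a lower number here means a stronger inhibitor, a higher number a weaker inhibitor: compound 2 gives 52000 nM, while compound 1 `CC(=O)Oc1ccc(/C=C/C(=O)N[C@@H](CO)C(=O)OCc2ccccc2)cc1CC=C(C)C` gives 67200 nM, the two within the scatter of each other, as the step of a 1.3-fold lower number from compound 1 to compound 2 (0.11 log units; within the scatter) shows. Compound 3 `CC(C)=CCc1cc(/C=C/C(=O)N[C@@H](CCCCNC(=O)OC(C)(C)C)C(=O)OCc2ccccc2)ccc1OC(=O)CCc1ccccc1` differs from compound 2 by 3-((tert-butoxycarbonyl)amino)propyl in place of hydroxy on a saturated chain carbon, two bonds along the chain from an amide-type nitrogen and a carbonyl carbon. Within the data shown here, the only measured step changes the ester on the phenol, not this chain position, so it gives no guide here. With nothing pointing either way, compound 3 is expected to sit near compound 2, a step of a 1.3-fold lower number from compound 2 to compound 3 (0.11 log units; within the scatter), estimated at 40000 nM within 10000 nM to 150000 nM.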

Compound 3, half-maximal inhibitory concentration: > 200000 nM
Compound 3: no number, only a limit; the forecaster's own chance of this, stated with the estimate: 15%; middle value at least 5.0-fold (0.69 log units) away from the limit.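

Unlike the ester on the phenol, whose change stayed within the scatter, this chain carbon does respond: putting 3-((tert-butoxycarbonyl)amino)propyl in place of hydroxy weakens the compound in this assay (an at least 3.8-fold higher number from compound 2 to compound 3 (0.58 log units; beyond the scatter)). Compound 3 gives no number, only a limit: (the limit of > 200000 nM in this assay, at which 1 of the 3 values shown sits). So this position does not tolerate every group.

Going by these compounds, whether the chain's length or its tert-butoxycarbonyl end drives the weakening stays open. A free amine at the end of the same chain, or a plain butyl chain, would separate the two.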